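This account rests on a few compounds, and the source may have more. Where it says the series, first, only, none or still open, it means among the compounds named here.

Of the compounds shown here, two built on one shared core have been measured in a functional assay on the whole organism with Canis familiaris (Canis lupus familiaris) as the target, at a dose of 2 mg/kg by the intravenous route; a higher number here means a stronger effect of the compound at the dose given, a lower number a weaker effect. Compound 1 `CC(=O)Nc1c(C)nc2c(OCc3ccccc3)cccn12` gives 24%, and compound 2 `CCNc1c(C)nc2c(OCc3ccccc3)cccn12` gives 32%. Going by the values given here, the single measured step between them is a number 8 percentage points higher from compound 1 to compound 2 (within the scatter). On these numbers compound 2 stands at the upper end of the two, but its gap to compound 1 lies within the scatter, so the two cannot be placed in any order.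

Compound 3 `CCCNc1c(C)nc2c(OCc3ccccc3)cccn12` differs from compound 2 by one counted change: methyl in place of hydrogen on a saturated chain carbon, two bonds along the chain from a nitrogen on an aromatic ring. Among the compounds with values here, no measured step lengthens a chain in this way; the only known step exchanges an acetyl for an ethyl, a different kind of change, and was itself within the scatter. No step beyond the scatter is therefore expected in this assay. Compound 3 is estimated at 32%, between 15% and 50%, which means an expected step of no change at the digits printed from compound 2 to compound 3 (within the scatter).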

Compound 3, a percentage reported as inhibition, in the whole organism at one dose (the size of the read-out at that dose, not a potency): 12%
The estimate for compound 3 lay 20 percentage points above the measured number, outside the stated range (below it).
By their numbers in this assay, from the lowest: compound 3; then compounds 1 and 2 (each within the scatter of the next).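

In this assay the group on the nitrogen on an aromatic ring now makes a difference that can be read: ethyl to propyl, a single added methyl on a saturated chain carbon, gives a number 20 percentage points lower from compound 2 to compound 3 (beyond the scatter) and so shows that even this small change can matter at this position. Propyl in place of acetyl likewise gives a number 12 percentage points lower from compound 1 to compound 3 (beyond the scatter) in contrast to ethyl in place of acetyl, which gave only a number 8 percentage points higher from compound 1 to compound 2 (within the scatter) and could not separate those two compounds. No measurement at hand offers a reason for this fall.

As far as these compounds go, whether a longer chain such as butyl on this nitrogen would bring the number down further remains open. Also open, from the compounds shown here alone, is where the plain amine, with no carbon group on the nitrogen, or a branched group such as isopropyl would stand.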